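The source may hold more compounds than are shown below. What is called first, only, known or untested is meant among the compounds shown, and "the series" means these compounds.

Compound 1 `COc1cccc(-c2ccc(C(=O)N(Cc3cccc(OCCCCCC(=O)O)c3)C(C)C)cc2)c1` was tested in an ADME assay on BJ cells (Homo sapiens) for cytotoxicity, read by CellTiter-Glo and resazurin assay, with a stated time of 72 h (a higher number here means that more compound is needed for the effect, a lower number that less compound is needed), and compound 1 reaches only a limit there, > 20900 nM. Compound 2 `CCOc1cccc(-c2ccc(C(=O)N(Cc3cccc(OCCCCCC(=O)O)c3)C(C)C)cc2)c1`, in this assay, also reaches only a limit, > 20800 nM. The step that the two limits leave unreadable from compound 1 to compound 2 therefore cannot be read, as both values sit at limits (the limit of > 20800 nM in this assay, at which 1 of the 3 values shown sits, (the limit of > 20900 nM in this assay, at which 1 of the 3 values shown sits)). Compound 3 `CC(C)N(Cc1cccc(OCCCCCC(=O)O)c1)C(=O)c1ccc(-c2cc3ccccc3n2S(=O)(=O)c2ccccc2)cc1`, in this assay, again gives only a limit, > 26000 nM (the limit of > 26000 nM in this assay, at which 1 of the 3 values shown sits). Thus no measured value falls below a limit, and no step of readable size exists to draw on. Compound 4 `CC(C)N(Cc1cccc(OCCCCCC(=O)O)c1)C(=O)c1ccc(-c2ccc(Cl)c(Cl)c2)cc1` differs from compound 1 by 3,4-dichlorophenyl in place of 3-methoxyphenyl on an aromatic carbon. With every measured compound at a limit, compound 4 is expected to take no step beyond the scatter, a step that the limit leaves unreadable from compound 1 to compound 4. Compound 4 is therefore estimated at 25000 nM, within 9000 nM to 60000 nM, most likely again only a limit.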

Compound 4, half-maximal effective concentration: > 26000 nM
Compound 4: no number, only a limit (the forecaster's own chance of this, stated with the estimate: 85%); at least 1.0-fold (0.01 log units) between middle value and limit.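

Compound 4 also gives only a limit, so the steps to it from compound 1 and compound 2 cannot be read. The compounds shown leave open what concentration any of them needs for the half-maximal effect in this assay.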